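Swapping the Aryl Group on a Shared Core

The source may report more compounds than this note shows. Statements on the series, on what has been measured and on what is new or still open speak of the compounds shown alone.

Of the compounds shown here, three built on one shared core have been tested in a functional assay on MCF7 cells (Homo sapiens) for cytotoxicity, read by MTT assay, with a stated time of 48 h; a lower number here means a stronger inhibitor, a higher number a weaker inhibitor. Compound 1 `Cc1ccccc1-c1nnc(SCCn2c([N+](=O)[O-])cnc2C)o1` gives 15800 nM in this assay. Compound 2 `COc1ccc(-c2nnc(SCCn3c([N+](=O)[O-])cnc3C)o2)cc1` gives 10600 nM, and compound 3 `Cc1ncc([N+](=O)[O-])n1CCSc1nnc(-c2ccc(F)cc2)o1` gives 8100 nM. Among these three numbers compound 2 stands second highest; its nearest neighbour is compound 3, with a 1.3-fold lower number from compound 2 to compound 3 (0.12 log units; within the scatter), and its furthest is compound 1, with a 1.5-fold lower number from compound 1 to compound 2 (0.17 log units; within the scatter). Every step between the measured compounds, including a 2.0-fold lower number from compound 1 to compound 3 (0.29 log units; within the scatter), stays within the scatter, so this assay does not tell the three aryl groups apart.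

Compound 4 `Cc1ncc([N+](=O)[O-])n1CCSc1nnc(-c2ccc(N)nc2)o1` is not yet measured. It differs from compound 2 in one place: 6-aminopyridin-3-yl in place of 4-methoxyphenyl on an aromatic carbon. The change sits on the same aromatic carbon where the measured compounds already differ, and those steps were all small. Among the measured compounds shown here, the entering group brings a hydrogen-bond donor that none of the measured groups carries, for which the data give no direct guide. The expected step from compound 2 to compound 4 in this assay is a 1.1-fold lower number from compound 2 to compound 4 (0.03 log units; within the scatter), nothing beyond the scatter. Compound 4 is estimated to give 10000 nM in this assay, with a range from 4000 nM to 25000 nM.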

Compound 4, half-maximal inhibitory concentration: 26800 nM
Compound 4: the middle estimate sits 2.7-fold (0.43 log units) below what was measured, outside the stated range (above it).
By their numbers in this assay, from the lowest: compounds 3, 2, 1 and 4 (each within the scatter of the next, the first and the last beyond it).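

In this assay, among the compounds shown here, this position on the shared core now shows a real effect of the aryl group: a 2.5-fold higher number from compound 2 to compound 4 (0.40 log units; beyond the scatter) and a 3.3-fold higher number from compound 3 to compound 4 (0.52 log units; beyond the scatter) are both modest but beyond the scatter, which no step among the earlier compounds was. The 6-aminopyridin-3-yl group does not stand apart from every aryl group, though, as a 1.7-fold higher number from compound 1 to compound 4 (0.23 log units; within the scatter) stays within the scatter, so this change separates compound 4 only from compound 2 and compound 3. No supporting data bear on why the number rises.

The new group differs from the others in both its ring nitrogen and its amine, and the compounds shown do not separate these two features. A phenyl ring carrying an amine, or a pyridine ring without one, would test each feature on its own.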